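Extending the methoxy of compound 3 to 2,2-difluoroethoxy

A few compounds are considered here, and "the series" means these few. Any claim that something is new, unique, unknown or untested is made for them only; others in the source may bear on it.

- compound 1 `CN1Cc2cc(ccc2S(=O)(=O)C2CC2)NC(=O)CCc2cccc(c2)[C@@H](Nc2ccc3c(N)ncc(F)c3c2)C1=O`: 67 nm/s
- compound 2 `COc1cc2cc(c1)[C@@H](Nc1ccc3c(N)ncc(F)c3c1)C(=O)N(C)Cc1cc(ccc1S(=O)(=O)C1CC1)NC(=O)CC2`: 15 nm/s
- compound 3 `COc1ccc2cc1CCC(=O)Nc1ccc(S(=O)(=O)C3CC3)c(c1)CN(C)C(=O)[C@@H]2Nc1ccc2c(N)ncc(F)c2c1`: 350 nm/s

In an ADME assay for permeability, using PAMPA, at pH 5.5 (a higher number here means that the compound crosses the layer faster, a lower number that the compound crosses the layer more slowly), compound 3 has the highest of the three numbers, at 350 nm/s. Compound 4 `CN1Cc2cc(ccc2S(=O)(=O)C2CC2)NC(=O)CCc2cc(ccc2OCC(F)F)[C@@H](Nc2ccc3c(N)ncc(F)c3c2)C1=O` has not yet been measured. It differs from compound 3 by difluoromethyl in place of hydrogen on a saturated chain carbon bound to an oxygen on an aromatic ring, or methoxy to 2,2-difluoroethoxy.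

Among the measured compounds shown here, two measured steps bear on this change, and both are modest. One is a 5.2-fold higher number from compound 1 to compound 3 (0.72 log units; beyond the scatter), and the other is a 4.5-fold lower number from compound 1 to compound 2 (0.65 log units; beyond the scatter). Each places a methoxy on an aromatic carbon, yet they run in opposite directions. Neither extends an existing methoxy, so the data set no direction for this change, and no shift beyond the scatter is expected. The expected step is a 1.2-fold lower number from compound 3 to compound 4 (0.07 log units; within the scatter), with wide uncertainty. Compound 4 is estimated at 300 nm/s, with an expected range from 100 nm/s to 800 nm/s.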

Compound 4, apparent permeability: 88 nm/s
For compound 4 the middle estimate is 3.4-fold (0.53 log units) above the measured one, and the stated range ends above it.
By their numbers in this assay, from the lowest: compound 2; then compounds 1 and 4 (each within the scatter of the next); then compound 3.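

In this assay, the methoxy of compound 3 does not tolerate extension without cost: adding difluoromethyl on the saturated chain carbon bound to the oxygen on the aromatic ring gives a 4.0-fold lower number from compound 3 to compound 4 (0.60 log units; beyond the scatter), the first step shown that alters an existing methoxy rather than placing one on an aromatic carbon. Measured against hydrogen on that aromatic carbon, 2,2-difluoroethoxy gives a 1.3-fold higher number from compound 1 to compound 4 (0.12 log units; within the scatter), so the rise seen with methoxy, a 5.2-fold higher number from compound 1 to compound 3 (0.72 log units; beyond the scatter), is absent from compound 4. Nothing shown here gives a reason for these steps.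

From the compounds shown here alone, whether the loss follows the longer chain or the two fluorine atoms stays open, and ethoxy or 2-fluoroethoxy at the same place would separate the two. Also open, going by these compounds, is how a hydroxy group would read at this place.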